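Methylsulfanyl in Place of Methyl: Tolerance of Compound 4

The source may report more compounds than this note shows. Statements on the series, on what has been measured and on what is new or still open speak of the compounds shown alone.

Three compounds have so far been measured in a functional assay on MT2 cells (Homo sapiens) for cytotoxicity; a lower number here means that less compound is tolerated, a higher number that more compound is tolerated:

compound 1, `CC(C)=CCOc1cc(Nc2nccs2)ccc1C#N`: 500 nM
compound 2, `CC(C)=CCOc1cc(Nc2nccc(C)n2)ccc1Cl`: < 200 nM
compound 3, `CC(C)=CCOc1cc(Nc2nccs2)ccc1Cl`: 26000 nM

Compound 2 stands at the low end of these numbers, but its reading is a limit of the assay and not a number; it sits at the limit of < 200 nM in this assay, at which 1 of the 3 values shown sits. Compound 4, `CSc1ccnc(Nc2ccc(Cl)c(OCC=C(C)C)c2)n1`, differs from compound 2 by a single change: methylsulfanyl in place of methyl on an aromatic carbon. Among the measured compounds shown here, two measured steps bear on it. The step of an at least 130-fold higher number from compound 2 to compound 3 (2.11 log units; beyond the scatter) replaces the whole group that carries the methyl in compound 2 and is large. The step of a 52-fold higher number from compound 1 to compound 3 (1.72 log units; beyond the scatter) is also large, though it concerns a different position of the core. The change from compound 2 to compound 4 is far smaller than either of these, so in this assay a step of modest size is expected, more likely upward than downward, since compound 2 is already at the limit. The expected step is an at least 3.0-fold higher number from compound 2 to compound 4 (0.47 log units; beyond the scatter). Compound 4 is therefore estimated at 600 nM, with a range from 150 nM to 4000 nM.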

Compound 4, half-maximal cytotoxic concentration: 2800 nM
Estimate against measurement, compound 4: 4.7-fold (0.67 log units) below; the measured number falls inside the stated range.
By their numbers in this assay, from the lowest: compound 1; then compound 4; then compound 3. At a limit, below all of these: compound 2.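

Methylsulfanyl in place of methyl gives an at least 14-fold higher number from compound 2 to compound 4 (1.14 log units; beyond the scatter) in this assay, the first change shown at this aromatic carbon, next to the ring nitrogen. The earlier steps shown here replaced the whole group on the nitrogen or exchanged chloro and cyano, whereas this one keeps the ring and alters a single substituent, and that alone moves the number beyond the scatter. The reading of compound 2 is a limit and not a number: the limit of < 200 nM in this assay, at which 1 of the 4 values shown sits.

On these data alone, how far this step reaches beyond its printed bound stays open, and so does whether the sulfur or simply the larger group matters. As far as these compounds go, whether a methoxy group, an amine or a longer chain on this carbon would move the number in the same direction also remains unknown.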